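Alpha-methyl on the benzylic carbon of compound 2

The source may report more compounds than this note shows. Statements on the series, on what has been measured and on what is new or still open speak of the compounds shown alone.

Measured compounds:
compound 1, `Oc1nc(NCC2CCCCC2)nc2ccc(Cl)cc12`, 80.3%
compound 2, `Oc1nc(NCc2ccccc2)nc2ccc(Cl)cc12`, 98.1%

In a functional assay on the whole organism (uterus) with Rattus norvegicus as the target, tested at 50 uM (on this read-out higher numbers stand for a weaker effect at the one concentration tested and lower numbers for a stronger effect), compound 2 gives the higher of the two numbers shown. Compound 1 lies below it, the difference being a number 17.8 percentage points higher from compound 1 to compound 2 (beyond the scatter). Compound 3, `C[C@H](Nc1nc(O)c2cc(Cl)ccc2n1)c1ccccc1`, is not yet measured; it differs from compound 2 as follows: methyl in place of hydrogen on a saturated chain carbon bound to an aromatic carbon and a nitrogen on an aromatic ring. For the measured compounds named here, the one measured step concerns the exchange of the cyclohexyl for a phenyl on the saturated chain carbon bound to a nitrogen on the aromatic ring, and it bears only loosely on a methyl entering on that carbon, since no pair here shows the effect of such a methyl. With compound 2 already at the weak end of the scale, the step in this assay from compound 2 to compound 3 is expected to stay within the scatter, a number 3.1 percentage points lower from compound 2 to compound 3 (within the scatter). For compound 3 the estimate is 95%, within 80% to 105%.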

Compound 3, a percentage reported as activity, at one concentration (the size of the read-out at that concentration, not a potency): 44.9%
Estimate against measurement, compound 3: 50.1 percentage points above, and the stated range ends above it.
By their numbers in this assay, from the lowest: compound 3; then compound 1; then compound 2.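

In this assay the saturated chain carbon bound to an aromatic carbon and a nitrogen on an aromatic ring proves highly sensitive to one added carbon: methyl in place of hydrogen gives a number 53.2 percentage points lower from compound 2 to compound 3 (beyond the scatter) and so moves the read-out towards a stronger effect. The earlier pair showed only the exchange of the ring carried by the chain, with a number 17.8 percentage points higher from compound 1 to compound 2 (beyond the scatter) as a modest step, whereas this large step shows that substitution on the chain carbon itself can matter more than that exchange. Nothing available explains why the methyl has this effect.

As far as these compounds go, it remains open whether an ethyl or a hydroxymethyl on the same carbon would extend or reverse the shift. Also open, from the compounds shown here alone, are how the mirror-image form of compound 3 would behave and whether the methyl would act similarly on compound 1.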